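From Compound 2 to Compound 3: A Larger Group

The source may report more compounds than this note shows. Statements on the series, on what has been measured and on what is new or still open speak of the compounds shown alone.

In a functional assay on LoVo cells (Homo sapiens) for inhibition, read by MTT assay, with a stated time of 48 h (on this read-out lower numbers stand for stronger inhibition and higher numbers for weaker inhibition), compound 1 (`COc1ccc(N(C)c2nc(C)nc3ccccc23)cc1OCC[Se]C#N`) gives 19 nM while compound 2 (`COc1ccc(N(C)c2nc(C)nc3ccccc23)cc1[Se]C#N`) gives 73 nM and so holds the higher of the two numbers. Compound 3 (`COc1ccc(N(C)c2nc(C)nc3ccccc23)cc1OCCCCC[Se]C#N`) has yet to be measured. Going from compound 2 to compound 3 brings a group of 9 heavy atoms (6 carbon, 1 nitrogen, 1 oxygen, 1 selenium; no ring) in place of a group of 3 heavy atoms (1 carbon, 1 nitrogen, 1 selenium; no ring), on an aromatic carbon in a single change. Among the compounds with values here, one measured step bears on this: a 3.8-fold higher number from compound 1 to compound 2 (0.58 log units; beyond the scatter) in a modest move beyond the scatter, where a group of 3 heavy atoms took the place of a group of 6 heavy atoms. Read backwards, that step ties the larger group to the lower number, but no measured compound carries a group as large as the one in compound 3, so the expectation is loose. A lower number of similar modest size is expected in this assay with a 2.9-fold lower number from compound 2 to compound 3 (0.47 log units; beyond the scatter) as the estimated step. For compound 3 the estimate is 25 nM within 8 nM to 80 nM as the expected span.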

Compound 3, half-maximal inhibitory concentration: 5210 nM
Compound 3: middle estimate off by 210-fold (2.32 log units), on the low side, and the stated range ends below it.
By their numbers in this assay, from the lowest: compound 1; then compound 2; then compound 3.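

In this assay the larger group does not go with the lower number at this position, and the step of a 71-fold higher number from compound 2 to compound 3 (1.85 log units; beyond the scatter) runs opposite to the direction that the earlier pair suggested. Within the data shown here, with the oxygen on the aromatic ring kept in place, the step of a 270-fold higher number from compound 1 to compound 3 (2.44 log units; beyond the scatter) shows that lengthening the saturated chain alone can produce a large change, larger than the one between the earlier compounds, so the lowest number of the three belongs to the mid-sized group of compound 1. Nothing measured here accounts for this reversal.

The three compounds do not show whether the number climbs gradually or abruptly across chains of intermediate length between compound 1 and compound 3. They also leave open whether a thiocyanate, with sulfur in place of selenium, would follow the same course.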